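Compound 3 and the methyl on its hydroxy group

The compounds below may be only part of what the source reports. "The series", "measured", "known", "first", "only" and "open" are said of these compounds alone.

Measured in a functional assay on A549 cells (Homo sapiens) for cytotoxicity, read by sulforhodamine B assay, with a stated time of 48 h; on this read-out lower numbers stand for stronger inhibition and higher numbers for weaker inhibition:
Compound 1 `COc1ccc(/C=C/C(=O)c2cccc(-c3ccc(F)cc3)c2)cc1` gives 11200 nM
Compound 2 `COc1cc(/C=C/C(=O)c2cccc(-c3cccc(F)c3)c2)ccc1O` gives 9900 nM
Compound 3 `COc1ccc(/C=C/C(=O)c2cccc(-c3cccc(F)c3)c2)cc1O` gives 500 nM

Compound 3 (at 500 nM) has the lowest number of the three and stands beyond the scatter from both others. Compound 4 `COc1ccc(/C=C/C(=O)c2cccc(-c3cccc(F)c3)c2)cc1OC` differs from it by methyl in place of hydrogen on an oxygen on an aromatic ring in one place, with methyl in place of hydrogen on an oxygen on an aromatic ring, so hydroxy becomes methoxy. Going by the values given here, no measured pair shows this change alone. The two higher values, compound 2 (at 9900 nM) and compound 1 (at 11200 nM), suggest that the low number of compound 3 is not easily kept. A move to a higher number, beyond the scatter, is expected, with an 8.0-fold higher number from compound 3 to compound 4 (0.90 log units; beyond the scatter) as the estimated step. Compound 4 is estimated at 4000 nM with an expected range from 1200 nM to 14000 nM in this read-out.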

Compound 4, half-maximal inhibitory concentration: 1940 nM
Beside the measured number, compound 4's estimate is 2.1-fold (0.31 log units) above it; measured number inside the range.
By their numbers in this assay, from the lowest: compound 3; then compound 4; then compounds 2 and 1 (each within the scatter of the next).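

In this assay the same change, methyl in place of hydrogen on an oxygen on an aromatic ring, gives a 3.9-fold higher number from compound 3 to compound 4 (0.59 log units; beyond the scatter) on one oxygen and a 5.1-fold lower number from compound 2 to compound 4 (0.71 log units; beyond the scatter) on the other, so hydroxy to methoxy has no single direction here. The outcome depends on which oxygen carries the hydrogen, and compound 4 sits between the two hydroxy compounds. Nothing at hand explains this reversal. Still open, on these data alone, is how an ethoxy group or an amine in place of the hydroxy group of compound 3 would read.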